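A few compounds are considered here, and "the series" means these few. Any claim that something is new, unique, unknown or untested is made for them only; others in the source may bear on it.

Compound 3 `CCCc1cn(C(c2ccccc2)c2cc3cc(Br)ccc3nc2OC)nn1` gives 11.3% in an ADME assay on PANC-1 cells (Homo sapiens) for cytotoxicity, read by sulforhodamine B assay, with a stated time of 48 h, tested at 10 uM; a lower number here means less inhibition, a higher number more inhibition at the concentration tested (going by the name of the read-out). Its number is the smallest of the three measured, yet compound 2 `CCOC(=O)c1cn(C(c2ccccc2)c2cc3cc(Br)ccc3nc2OC)nn1` with 15.4% and compound 1 `CCCCCCCc1cn(C(c2ccccc2)c2cc3cc(Br)ccc3nc2OC)nn1` with 16.6% both sit within the scatter of it. Compound 4 `COc1nc2ccc(Br)cc2cc1C(c1ccccc1)n1cc(-c2ccc(F)cc2)nn1` carries 4-fluorophenyl in place of propyl on an aromatic carbon. Every measured step altered the group on that same five-membered ring and none moved the read-out beyond the scatter: a number 1.2 percentage points lower from compound 1 to compound 2 (within the scatter), a number 4.1 percentage points lower from compound 2 to compound 3 (within the scatter) and a number 5.3 percentage points lower from compound 1 to compound 3 (within the scatter). Exchanging propyl for 4-fluorophenyl is a bigger change than any of those, so a step beyond the scatter cannot be ruled out, but nothing measured points in either direction. Compound 4 is therefore expected to give 15%, between 4% and 30%, which means an expected step of a number 3.7 percentage points higher from compound 3 to compound 4 (within the scatter), likely within the scatter.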

Compound 4, a percentage reported as inhibition, at one concentration (the size of the read-out at that concentration, not a potency): 14.9%
Compound 4: middle estimate off by 0.1 percentage points, on the high side; low and high end bracket the measured number.
By their numbers in this assay, from the lowest: compounds 3, 4, 2 and 1 (each within the scatter of the next).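

Placing an aromatic ring on this carbon, where the earlier groups had none, still leaves this assay within the scatter: there is a number 3.6 percentage points higher from compound 3 to compound 4 (within the scatter), a number 0.5 percentage points lower from compound 2 to compound 4 (within the scatter) and a number 1.7 percentage points lower from compound 1 to compound 4 (within the scatter). Across these four compounds, 4-fluorophenyl therefore cannot be told apart from propyl, ethoxycarbonyl or heptyl at this position. No evidence bears on why these numbers stay so close. Still open, on these data alone, is whether an amine or a carboxylic acid on this carbon would give a step beyond the scatter. Changes elsewhere on the shared core also remain untested here.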